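One bromine for two chlorines: compound 3 to compound 4

The source may hold more compounds than are shown below. What is called first, only, known or untested is meant among the compounds shown, and "the series" means these compounds.

Compound 3 `C=CCn1c(=O)/c(=C\c2ccc(Cl)c(Cl)c2)[nH]c(=O)/c1=C\c1ccccc1OC` gives "not active" (no number reported) in a functional assay on BGC-823 cells (Homo sapiens) for cytotoxicity, read by CCK-8 assay, with a stated time of 72 h (on this read-out lower numbers stand for stronger inhibition and higher numbers for weaker inhibition), with no numerical value given, so it stands apart from the two compounds of this series that carry numbers. Among the compounds with values here, compound 1 `C=CCn1c(=O)/c(=C\c2cccc(F)c2)[nH]c(=O)/c1=C\c1ccccc1OC` gives 5600 nM in this assay, and compound 2 `C=CCn1c(=O)/c(=C\c2ccccc2Cl)[nH]c(=O)/c1=C\c1ccccc1OC` gives 4600 nM; the step of a 1.2-fold lower number from compound 1 to compound 2 (0.09 log units; within the scatter) is the only measured step here and lies within the scatter. Compound 4 `C=CCn1c(=O)/c(=C\c2cccc(Br)c2)[nH]c(=O)/c1=C\c1ccccc1OC` differs from compound 3 by 3-bromophenyl in place of 3,4-dichlorophenyl on a double-bonded chain carbon bound to an aromatic carbon. Within the data shown here, no measured step covers a change of this kind, so neither size nor direction can be read from the series. Compound 1 carries 3-fluorophenyl, the closest analogue of the entering 3-bromophenyl, and its value 5600 nM is taken as the anchor. Compound 4 is expected to give about 5000 nM, within 2000 nM to 15000 nM.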

Compound 4, half-maximal inhibitory concentration: 5900 nM
Estimate against measurement, compound 4: 1.2-fold (0.07 log units) below; the measured number falls inside the stated range.
By their numbers in this assay, from the lowest: compounds 2, 1 and 4 (each within the scatter of the next).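

In this assay bromo in place of fluoro on an aromatic carbon gives a step within the scatter (a 1.1-fold higher number from compound 1 to compound 4 (0.02 log units; within the scatter)), and 3-bromophenyl in place of 2-chlorophenyl does too (a 1.3-fold higher number from compound 2 to compound 4 (0.11 log units; within the scatter)). At this place, on a double-bonded chain carbon bound to an aromatic carbon, 3-bromophenyl therefore joins 3-fluorophenyl and 2-chlorophenyl among the groups giving a number, while compound 3 with 3,4-dichlorophenyl has none. Going by these compounds, whether an amine or a carboxylic acid in place of the halogen would still give a number remains open. Nothing available explains why compound 3 stands apart from compound 4.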